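The source may report more compounds than this note shows. Statements on the series, on what has been measured and on what is new or still open speak of the compounds shown alone.

Working notes on the series in a functional assay on K562 cells (Homo sapiens) for cytotoxicity, read by MTT assay, with a stated time of 72 h; a higher number here means that more compound is tolerated, a lower number that less compound is tolerated. Compound 1 `CS/C(=N\C(=O)c1ccco1)NC(=O)c1ccco1` gives only a limit of the assay in this assay, > 100000 nM. Compound 2 `O=C(/N=C(/NC(=O)c1cc(-c2ccccc2)nc2ccccc12)[Se]Cc1ccccc1)c1cc(-c2ccccc2)nc2ccccc12` gives 88900 nM in this assay. Compound 3 `CS/C(=N\C(=O)c1cc(-c2ccccc2)nc2ccccc12)NC(=O)c1cc(-c2ccccc2)nc2ccccc12` also gives only a limit of the assay in this assay, > 100000 nM. Compound 3 thus stands at the ceiling of the numbers shown, without a number of its own, as recorded by the limit of > 100000 nM in this assay, at which 2 of the 3 values shown sit. Within the data shown here, the one measured step that touches the carbon with the double bond to nitrogen is an at least 1.1-fold higher number from compound 2 to compound 3 (0.05 log units; that floor lies within the scatter), and it lies within the scatter.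

Compound 4 `C[Se]/C(=N\C(=O)c1cc(-c2ccccc2)nc2ccccc12)NC(=O)c1cc(-c2ccccc2)nc2ccccc12` differs from compound 3 by a group of 2 heavy atoms (1 carbon, 1 selenium; no ring) in place of a group of 2 heavy atoms (1 carbon, 1 sulfur; no ring), on a carbon with a double bond to nitrogen. The only measured step that bears on this exchange is the one from compound 2 to compound 3 given above, and it stayed within the scatter, so no step beyond the scatter is expected in this assay, in either direction, and a further limit is the likelier outcome. Compound 4 is expected to give 95000 nM in this assay, with a range from 40000 nM to 200000 nM. The step this estimate means, an at least 1.0-fold lower number from compound 3 to compound 4 (0.02 log units; that floor lies within the scatter), is expected to stay within the scatter.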

Compound 4, concentration lethal to 50% of the cells: 73100 nM
Beside the measured number, compound 4's estimate is 1.3-fold (0.11 log units) above it, and the stated range covers the measured number.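

In this assay, among these compounds, the selenium-bearing group entering in place of methylsulfanyl, on a carbon with a double bond to nitrogen, gives the first direct comparison of the two chalcogens on the shared core: an at least 1.3-fold lower number from compound 3 to compound 4 (0.13 log units; that floor lies within the scatter). This step can be read only as a floor, because compound 3 rests on a limit of the assay and has no number of its own: the limit of > 100000 nM in this assay, at which 2 of the 4 values shown sit. With selenium kept, hydrogen in place of phenyl on a saturated chain carbon bound to a selenium atom gives a 1.2-fold lower number from compound 2 to compound 4 (0.08 log units; within the scatter), so this change also leaves the number within the scatter.

From the compounds shown here alone, whether an amine or a longer chain such as hexyl on the same carbon would move the number beyond the scatter remains open. Also open, going by these compounds, is how the same exchange of sulfur for selenium reads on the core of compound 1.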